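A few compounds are considered here, and "the series" means these few. Any claim that something is new, unique, unknown or untested is made for them only; others in the source may bear on it.

Measured compounds, read in a functional assay on HT-29 cells (Homo sapiens) for cytotoxicity, read by MTT assay, with a stated time of 72 h; on this read-out higher numbers stand for weaker inhibition and lower numbers for stronger inhibition:

compound 1, `COc1cc2c(Oc3ccc(NC(=O)c4cc(-c5ccc(C(F)(F)F)cc5)ccn4)cc3F)ccnc2cc1OCCCN1CCCCC1`: compound 1 gives 230 nM
compound 2, `COc1cc2c(Oc3ccc(NC(=O)c4cc(-c5ccccc5)ccn4)cc3F)ccnc2cc1OCCCN1CCCC1`: compound 2 gives 120 nM
compound 3, `COc1cc2c(Oc3ccc(NC(=O)c4cc(-c5ccc(C(F)(F)F)cc5)ccn4)cc3F)ccnc2cc1OCCCN1CCCC1`: compound 3 gives 720 nM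

Compound 2 stands at the low end of the three numbers; its gap to compound 1 lies within the scatter, so no order between those two is claimed, while the gap to compound 3 is beyond it. Compound 3 and compound 1 share one core and differ only in the ring at the end of the chain, (piperidin-1-yl in place of pyrrolidin-1-yl on a saturated chain carbon, three bonds along the chain from an oxygen on an aromatic ring), and that change gave a 3.1-fold lower number from compound 3 to compound 1 (0.50 log units; beyond the scatter) in this assay. Compound 3 and compound 2 differ only in the core, (hydrogen in place of trifluoromethyl on an aromatic carbon), and that difference reads a 6.0-fold higher number from compound 2 to compound 3 (0.78 log units; beyond the scatter) in this assay.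

Compound 4, `COc1cc2c(Oc3ccc(NC(=O)c4cc(-c5ccccc5)ccn4)cc3F)ccnc2cc1OCCCN1CCCCC1`, is not yet measured. It relates to compound 2 by piperidin-1-yl in place of pyrrolidin-1-yl on a saturated chain carbon, three bonds along the chain from an oxygen on an aromatic ring. This is the same change as from compound 3 to compound 1; the place is described in the same words in both cases, so the change is the same, carried onto the core of compound 2 rather than that of compound 3. One prior example is a thin basis, and compound 2 already sits at the low end, so the step is expected to carry over only in part.

For compound 4 in this assay the estimated step is a 2.2-fold lower number from compound 2 to compound 4 (0.34 log units; beyond the scatter), resting on compound 1 and compound 3 and their step of a 3.1-fold lower number from compound 3 to compound 1 (0.50 log units; beyond the scatter). Compound 4 is therefore estimated at 55 nM, with a likely range from 25 nM to 140 nM.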

Compound 4, half-maximal inhibitory concentration: 270 nM
For compound 4 the middle estimate is 4.9-fold (0.69 log units) below the measured one; the measured number lies above the stated range.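

On the core without trifluoromethyl, piperidin-1-yl in place of pyrrolidin-1-yl gives a 2.3-fold higher number from compound 2 to compound 4 (0.35 log units; beyond the scatter), so in this assay this change does not carry over from the trifluoromethyl core and instead runs in the opposite direction: the same change on two cores in this assay, a 3.1-fold lower number (0.50 log units; beyond the scatter) from compound 3 to compound 1 and a 2.3-fold higher number (0.35 log units; beyond the scatter) from compound 2 to compound 4, 7.0-fold (0.85 log units) apart, beyond the scatter of two such steps

The four compounds form a closed square, and the second side tells the same story: hydrogen in place of trifluoromethyl gives a 1.2-fold higher number from compound 1 to compound 4 (0.07 log units; within the scatter) with piperidin-1-yl at the chain end, so no difference is claimed there, whereas the same change is beyond the scatter with pyrrolidin-1-yl at the chain end: the same change on two cores in this assay, a 6.0-fold higher number (0.78 log units; beyond the scatter) from compound 2 to compound 3 and a 1.2-fold lower number (0.07 log units; within the scatter) from compound 4 to compound 1, 7.0-fold (0.85 log units) apart, beyond the scatter of two such steps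

This shows that, within these four compounds, the effect of neither change can be read independently of the other, so a step measured on one core is a poor guide to the next; it does not show why the two changes interact, and with one pair per core it gives no rule for any other core or any other assay.

The compounds shown leave open how another amine at the chain end, such as morpholin-4-yl or 4-methylpiperazin-1-yl, or a shorter chain such as 2-(piperidin-1-yl)ethyl, would behave on these two cores. They also leave open whether chlorine or methoxy in place of trifluoromethyl would give the same interaction.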